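A few compounds are considered here, and "the series" means these few. Any claim that something is new, unique, unknown or untested is made for them only; others in the source may bear on it.

In an ADME assay on J774 cells (Mus musculus) for cytotoxicity, with a stated time of 72 h (on this read-out lower numbers stand for an effect already at smaller amounts and higher numbers for an effect only at larger amounts of compound), three compounds have been measured so far:

- Compound 1 `COc1cc2[nH]c(C)c(-c3ccc(N4CCN(C)CC4)nc3)c(=O)c2cc1Cl`: > 25100 nM
- Compound 2 `COc1cc2[nH]c(C)c(-c3cc4ccccc4s3)c(=O)c2cc1Cl`: > 28100 nM
- Compound 3 `COc1cc2[nH]c(C)c(-c3ccc(C(F)(F)F)cc3F)c(=O)c2cc1Cl`: > 25900 nM

All three entries are limits of the assay and not numbers, so no order can be read among them. Compound 3 stands at its limit of > 25900 nM. Among the measured compounds shown here, no two of the measured compounds differ in only one place, so no measured step is available as a guide.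

The next compound is compound 4 `COc1cc2[nH]c(C)c(-c3ccc(C(F)(F)F)cc3C)c(=O)c2cc1Cl`. It departs from compound 3 by one exchange, methyl in place of fluoro on an aromatic carbon, ortho to a large group and meta to a trifluoromethyl group (methyl in place of fluoro on an aromatic carbon). The shared core and the rest of the molecule stay the same.

All three measured compounds, with their different groups, ended in a limit, and none goes against that pattern. The expectation therefore rests on compound 3 and its limit of > 25900 nM. No change beyond the usual scatter is expected in this assay, and the expected step is a step that the limit leaves unreadable from compound 3 to compound 4. Compound 4 is estimated at 26000 nM, with an expected range from 13000 nM to 40000 nM. A report of only a limit is the likeliest outcome for this compound.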

Compound 4, half-maximal effective concentration: > 26200 nM
Compound 4 gave a limit, no number; the forecaster's own chance of this, stated with the estimate: 85%; at least 1.0-fold (0.00 log units) between middle value and limit.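

In this assay compound 4 gives > 26200 nM, which is a limit of the assay and not a number. Compound 3 also stands at a limit, so no step can be read from compound 3 to compound 4. The compounds shown leave open whether methyl in place of fluoro changes this read-out at all.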